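Compound 3 to compound 4: a difluorophenyl swap

This account rests on a few compounds, and the source may have more. Where it says the series, first, only, none or still open, it means among the compounds named here.

Compound 1 (`C=C[C@@](C)(/C=C/c1ccc(Nc2ccc(OC)cc2)cc1)CCC=C(C)C`), compound 2 (`C=C[C@@](C)(/C=C/c1ccc(Nc2ccc(F)cc2)cc1)CCC=C(C)C`) and compound 3 (`C=C[C@@](C)(/C=C/c1ccc(Nc2ccc(F)c(F)c2)cc1)CCC=C(C)C`) share one core and differ in the aromatic group on the nitrogen. In a functional assay on HepG2 cells (Homo sapiens) for cytotoxicity, with a stated time of 72 h (a lower number here means that less compound is needed, a higher number that more compound is needed for the effect), compound 1 gives > 52000 nM, which is a limit of the assay. Compound 2 gives > 52000 nM, also a limit. Compound 3 gives > 52000 nM, again a limit and not a number. The set stands together: the limit of > 52000 nM in this assay, at which 3 of the 3 values shown sit.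

Compound 4 (`C=C[C@@](C)(/C=C/c1ccc(Nc2cc(F)cc(F)c2)cc1)CCC=C(C)C`) carries 3,5-difluorophenyl in place of 3,4-difluorophenyl on a nitrogen on an aromatic ring.

Three measured steps change this same group: a step that the two limits leave unreadable from compound 1 to compound 2, a step that the two limits leave unreadable from compound 1 to compound 3 and a step that the two limits leave unreadable from compound 2 to compound 3. None gives a size, and none produced a number in this assay. No step beyond the scatter is therefore expected, and no direction can be assigned. The expected step is a step that the limit leaves unreadable from compound 3 to compound 4. Compound 4 is expected at 60000 nM, with an estimated range from 30000 nM to 100000 nM, and will most likely be reported as a limit again.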

Compound 4, half-maximal effective concentration: > 52000 nM
Compound 4 gave a limit, no number (the forecaster's own chance of this, stated with the estimate: 90%); the middle value is on the limit's open side.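

No new step can be read between compound 4 and compound 1, compound 2 or compound 3, since each value is a limit and not a number: the limit of > 52000 nM in this assay, at which 4 of the 4 values shown sit.

The compounds shown leave open whether any aromatic group on the nitrogen gives a measurable value in this assay.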